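An Amino Group Added to the Core of Compound 1

The source may report more compounds than this note shows. Statements on the series, on what has been measured and on what is new or still open speak of the compounds shown alone.

Measured so far:
compound 1 `COc1ccc(/C=C/C(=O)c2cccc(-c3ccc(F)cc3)c2)cc1`: > 50000 nM
compound 2 `COc1ccc(/C=C/C(=O)c2ccc(NC(C)=O)c(-c3ccc(F)cc3)c2)cc1OC`: 2650 nM

In an assay on A549 cells for inhibition of transcription factor p65 (Homo sapiens), read by fluorescence, with a stated time of 2 h (on this read-out higher numbers stand for weaker inhibition and lower numbers for stronger inhibition), compound 1 gives > 50000 nM, which is a limit of the assay and not a number. Compound 1 therefore sits at the limit of > 50000 nM in this assay, at which 1 of the 2 values shown sits, the weak end of the numbers shown. Compound 2 gives 2650 nM in this assay, a measured value. Compound 3 `COc1ccc(/C=C/C(=O)c2ccc(N)c(-c3ccc(F)cc3)c2)cc1` differs from compound 1 by amino in place of hydrogen on an aromatic carbon. For the measured compounds named here, no step between measured compounds is known, so the expectation rests on compound 1 alone. The step is expected to be an at least 6.2-fold lower number from compound 1 to compound 3 (0.79 log units; beyond the scatter), toward stronger inhibition. Compound 3 is estimated at 8000 nM, between 1500 nM and 50000 nM.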

Compound 3, half-maximal inhibitory concentration: > 50000 nM
Compound 3: a limit, no number; the forecaster's own chance of this, stated with the estimate: 35%; middle value at least 6.2-fold (0.79 log units) from the limit.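

Compound 1 and compound 3 both give a limit of the assay and not a number, so no step can be read between them: the limit of > 50000 nM in this assay, at which 2 of the 3 values shown sit.

The compounds shown leave open whether amino in place of hydrogen on an aromatic carbon changes inhibition at all, and by how much.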